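Shortening the acid-bearing chain attached to the sulfur

A few compounds are considered here, and "the series" means these few. Any claim that something is new, unique, unknown or untested is made for them only; others in the source may bear on it.

Measured compounds:
compound 1 `CSc1ccn([C@@H]2O[C@H](COP(=O)(O)OP(=O)(O)O)[C@@H](O)[C@H]2O)c(=O)n1` — 2300 nM
compound 2 `O=C(O)CCCSc1ccn([C@@H]2O[C@H](COP(=O)(O)OP(=O)(O)O)[C@@H](O)[C@H]2O)c(=O)n1` — 8800 nM

Of the compounds shown here, two have so far been tested in an in vitro functional assay on 1321-N1 cells for agonist activity at P2Y purinoceptor 6 (Homo sapiens); a lower number here means that less compound is needed, a higher number that more compound is needed for the effect. Compound 1 gives 2300 nM there, and compound 2, bearing 2-carboxyethyl in place of hydrogen on a saturated chain carbon bound to a sulfur, gives 8800 nM. Compound 2 therefore stands highest of the two numbers, reached through a 3.8-fold higher number from compound 1 to compound 2 (0.58 log units; beyond the scatter), a modest shift beyond the scatter.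

Compound 3 `O=C(O)CCSc1ccn([C@@H]2O[C@H](COP(=O)(O)OP(=O)(O)O)[C@@H](O)[C@H]2O)c(=O)n1` differs from compound 2 by carboxy in place of carboxymethyl on a saturated chain carbon, two bonds along the chain from a sulfur. For the measured compounds named here, the single measured step that bears on this change is a 3.8-fold higher number from compound 1 to compound 2 (0.58 log units; beyond the scatter), which showed that adding the acid-bearing chain raised the number. Compound 3 keeps the acid but on a shorter chain, so a value between compound 1 and compound 2 seems the natural expectation, a small downward step from compound 2. Compound 3 is accordingly estimated at 5000 nM, with a range from 1800 nM to 14000 nM. The expected step from compound 2 is a 1.8-fold lower number from compound 2 to compound 3 (0.25 log units; within the scatter).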

Compound 3, half-maximal effective concentration: 1100 nM
Estimate against measurement, compound 3: 4.5-fold (0.66 log units) above, outside the stated range (below it).
By their numbers in this assay, from the lowest: compound 3; then compound 1; then compound 2.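

In this assay, the group on the sulfur proved sensitive to the length of the chain: going from (3-carboxypropyl)sulfanyl to (2-carboxyethyl)sulfanyl gave an 8.0-fold lower number from compound 2 to compound 3 (0.90 log units; beyond the scatter). An acid-bearing chain therefore does not always raise the number, since the shorter chain reverses the direction seen earlier and gives a 2.1-fold lower number from compound 1 to compound 3 (0.32 log units; beyond the scatter), a step only slightly beyond the usual scatter. Nothing available explains this reversal.

The compounds shown leave open whether the number would keep falling with a carboxymethyl group on the sulfur or would rise again, so the best chain length remains undefined. They also cannot show whether the carboxylic acid itself matters, or whether an ester, an amide or an amine at the end of the same chain would give a similar number.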